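Removing a ring methyl on two pyridine amidrazone thiosemicarbazides

A few compounds are considered here, and "the series" means these few. Any claim that something is new, unique, unknown or untested is made for them only; others in the source may bear on it.

The study compares three measured compounds and one still to be measured. Compound 1 `N/C(=N\NC(=S)N1CCOCC1)c1ccccn1` gives 7300 nM in a functional assay on HeLa cells (Homo sapiens) for cytotoxicity, read by MTT assay, with a stated time of 72 h; on this read-out lower numbers stand for stronger inhibition and higher numbers for weaker inhibition. Compound 2 `Cc1ccnc(/C(N)=N/NC(=S)N2CCOCC2)c1` gives 38500 nM in this assay, and compound 3 `Cc1cccc(/C(N)=N/NC(=S)N2CCCC2)n1` gives 2700 nM, the lowest number of the three. The step from compound 2 to compound 1 is a 5.3-fold lower number from compound 2 to compound 1 (0.72 log units; beyond the scatter), the change being (hydrogen in place of methyl on an aromatic carbon). How the core of compound 3 differs from that of compound 2 is not broken down here.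

Compound 4 `N/C(=N\NC(=S)N1CCCC1)c1ccccn1` is not yet measured. It differs from compound 3 by hydrogen in place of methyl on an aromatic carbon. This is the same kind of change as from compound 2 to compound 1, though not the same: there the methyl sat opposite the ring nitrogen, here it sits next to the ring nitrogen. Since the methyl leaves a different place, the earlier step is only a rough guide; the expected step from compound 3 to compound 4 in this assay is a 1.8-fold lower number from compound 3 to compound 4 (0.26 log units; within the scatter), a smaller shift than the measured one, with wide uncertainty. Compound 4 is thus expected to give about 1500 nM, between 500 nM and 5000 nM.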

Compound 4, half-maximal inhibitory concentration: 6200 nM
Compound 4: the middle estimate sits 4.1-fold (0.62 log units) below what was measured; measured number above the stated range.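

In this assay, taking the ring methyl off gives a 2.3-fold higher number from compound 3 to compound 4 (0.36 log units; beyond the scatter), so the same exchange of methyl for hydrogen moved the number in opposite directions on the two cores: the same change on two cores in this assay, a 5.3-fold lower number (0.72 log units; beyond the scatter) from compound 2 to compound 1 and a 2.3-fold higher number (0.36 log units; beyond the scatter) from compound 3 to compound 4, 12-fold (1.08 log units) apart, beyond the scatter of two such steps This shows that in this series the change does not carry from one core to another as a fixed step, not even in its direction, but it does not show whether the place the methyl leaves or the group on the thiocarbonyl carbon decides the outcome, as the two steps differ in both. Without a methyl, the comparison gives a 1.2-fold lower number from compound 1 to compound 4 (0.07 log units; within the scatter), so pyrrolidin-1-yl in place of morpholin-4-yl on a thiocarbonyl carbon has no effect that can be told from the scatter on this core.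

The compounds shown leave open what a methyl next to the ring nitrogen does when morpholin-4-yl sits on the thiocarbonyl carbon. Also open, going by these compounds, is whether an ethyl or a methoxy group in that place, or a piperidin-1-yl on the thiocarbonyl carbon, would follow either step.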